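Carbamoyl oxazolones against acid ceramidase: swapping the terminal phenyl

The source may hold more compounds than are shown below. What is called first, only, known or untested is meant among the compounds shown, and "the series" means these compounds.

Measured compounds:
Compound 1 `O=c1[nH]cc(-c2ccccc2)o1` — "not active" (no number reported)
Compound 2 `O=C(NCCCCc1ccccc1)n1cc(-c2ccccc2)oc1=O` — 90 nM

In an assay on isolated protein for inhibition of acid ceramidase (Homo sapiens), read by LC-MS, with a stated time of 1 h (on this read-out higher numbers stand for weaker inhibition and lower numbers for stronger inhibition), compound 1 comes out as "not active" (no number reported) and supplies no number. In this assay, among the compounds with values here, compound 2 gives 90 nM, which is the only number on record here; it stands alone, with compound 1 beside it as an entry without a value, so no comparison in numbers can be made between the two.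

Compound 3 `CCOCCNC(=O)n1cc(-c2ccccc2)oc1=O` has not yet been measured. It differs from compound 2 by ethoxy in place of phenethyl on a saturated chain carbon, two bonds along the chain from an amide-type nitrogen. Within the data shown here, no pair of measured compounds traces a comparable change, so the size of the step is open. Because compound 2 gives 90 nM with its phenethyl end intact, and the only inactive entry, compound 1, lacks the whole chain, the author expects the loss of the ring to cost potency rather than add to it, with a step from compound 2 to compound 3 of a 6.7-fold higher number from compound 2 to compound 3 (0.82 log units; beyond the scatter). For compound 3 an inhibitory concentration of 600 nM is estimated, within a range of 150 nM to 3000 nM.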

Compound 3, half-maximal inhibitory concentration: 2040 nM
Beside the measured number, compound 3's estimate is 3.4-fold (0.53 log units) below it; measured number inside the range.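

In this assay the exchange of phenethyl for ethoxy on a saturated chain carbon, two bonds along the chain from an amide-type nitrogen, gives a 23-fold higher number from compound 2 to compound 3 (1.36 log units; beyond the scatter) and is a large step beyond the scatter. The earlier compounds shown here showed only a chain against no chain, whereas this pair shows that a change confined to the end of the chain, with the rest of the carbamoyl oxazolone kept, moves the number strongly, even though compound 3 still gives a measurable inhibitory concentration. Nothing on record explains the size of this step.

The change does several things at once: the six-membered aromatic ring leaves, the group shrinks from 8 heavy atoms to 3, and an oxygen enters, so the compounds shown cannot assign the step to any one of these. Going by these compounds, a cyclohexyl group in place of the phenyl ring, or a plain propyl group in place of ethoxy, would each separate one of these changes from the others, and how a longer chain would fare at this position also stays open.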